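Removing a Methyl from the Core of Compound 2

The source may report more compounds than this note shows. Statements on the series, on what has been measured and on what is new or still open speak of the compounds shown alone.

Compound 1 `COc1cc(C2=NOC(c3c[nH]c4ccccc34)C2)cc(OC)c1OC` and compound 2 `Cc1[nH]c2ccccc2c1C1CC(c2ccncc2)=NO1` share a core but differ in more than one place, so only their two values can be set side by side. In a functional assay on LNCaP C4-2 cells (Homo sapiens) for inhibition, read by MTT assay, with a stated time of 48 h (a higher number here means a weaker inhibitor, a lower number a stronger inhibitor), compound 1 gives 5000 nM, while compound 2 gives 45100 nM, the higher of the two numbers by a gap beyond the scatter. Compound 3 `c1ccc2c(C3CC(c4ccncc4)=NO3)c[nH]c2c1` carries hydrogen in place of methyl on an aromatic carbon. Going by the values given here, no measured pair isolates this change, and compound 3 is expected to show a step of a 1.1-fold lower number from compound 2 to compound 3 (0.05 log units; within the scatter) that stays within the scatter. Compound 3 is therefore estimated at 40000 nM, between 15000 nM and 100000 nM.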

Compound 3, half-maximal inhibitory concentration: 12800 nM
Beside the measured number, compound 3's estimate is 3.1-fold (0.49 log units) above it; measured number below the stated range.
By their numbers in this assay, from the lowest: compound 1; then compound 3; then compound 2.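

In this assay the swap of methyl for hydrogen on this aromatic carbon gives a 3.5-fold lower number from compound 2 to compound 3 (0.55 log units; beyond the scatter) and so shows that this position affects the read-out, with a modest step beyond the scatter. Between these two compounds, the methyl goes with the weaker inhibition and the hydrogen with the stronger. No available evidence accounts for this step. From the compounds shown here alone, whether an ethyl group, a chlorine atom or an amine on the same carbon would give a lower or a higher number than hydrogen remains open.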